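Para-halogen swap on the alkoxyimino side chain: fluoro to iodo

A few compounds are considered here, and "the series" means these few. Any claim that something is new, unique, unknown or untested is made for them only; others in the source may bear on it.

Measured compounds:
compound 1 `O=c1[nH]/c(=N\OCCCCc2ccccc2)ccn1[C@@H]1O[C@H](COP(=O)(O)OP(=O)(O)OP(=O)(O)O)[C@@H](O)[C@H]1O` in a functional assay on 1321-N1 cells for agonist activity at P2Y purinoceptor 4 (Homo sapiens), read by scintillation counting and inositol phosphate accumulation (on this read-out lower numbers stand for an effect already at smaller amounts and higher numbers for an effect only at larger amounts of compound), gives 54 nM
compound 2 `O=c1[nH]/c(=N\OCCCc2ccc(F)cc2)ccn1[C@@H]1O[C@H](COP(=O)(O)OP(=O)(O)OP(=O)(O)O)[C@@H](O)[C@H]1O` in this assay gives 105 nM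

Among the measured compounds shown here, only one step among the measured compounds exists: a 1.9-fold higher number from compound 1 to compound 2 (0.29 log units; within the scatter). On these two numbers compound 2 sits next to compound 1 with a gap that does not exceed the scatter, so neither can be ranked against the other.

Compound 3 `O=c1[nH]/c(=N\OCCCc2ccc(I)cc2)ccn1[C@@H]1O[C@H](COP(=O)(O)OP(=O)(O)OP(=O)(O)O)[C@@H](O)[C@H]1O` is not yet measured. It differs from compound 2 by iodo in place of fluoro on an aromatic carbon. For the measured compounds named here, no measured step touches the para substituent of that ring, so the one available step bears only indirectly on it; that step was itself within the scatter. For compound 3 in this assay no change beyond the scatter is therefore expected, and the estimated step is a 1.1-fold lower number from compound 2 to compound 3 (0.02 log units; within the scatter). Compound 3 is expected to give 100 nM, with a range from 40 nM to 300 nM.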

Compound 3, half-maximal effective concentration: 91 nM
Beside the measured number, compound 3's estimate is 1.1-fold (0.04 log units) above it; measured number inside the range.
By their numbers in this assay, from the lowest: compounds 1, 3 and 2 (each within the scatter of the next).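

In this assay, among the compounds shown here, iodo in place of fluoro on the aromatic carbon para to a large group gives a 1.2-fold lower number from compound 2 to compound 3 (0.06 log units; within the scatter), so this halogen change, which the earlier compounds did not cover, cannot be told apart on this read-out. With 4-iodophenyl in place of benzyl on the saturated chain carbon, the listed step is a 1.7-fold higher number from compound 1 to compound 3 (0.23 log units; within the scatter), so compound 3 cannot be ranked against compound 1 either. No supporting data bear on this result.

Still open, as far as these compounds go, is whether an amine, a carboxylic acid or a methoxy group on the same aromatic carbon would stay within the scatter of these numbers. Also open, from the compounds shown here alone, is how a longer chain carrying the 4-iodophenyl group would read in this assay.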